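Series notes: from compound 3 to compound 4

The compounds below may be only part of what the source reports. "The series", "measured", "known", "first", "only" and "open" are said of these compounds alone.

Of the compounds shown here, three of the shared core have been measured in an assay on CHO cells for displacement of a labelled ligand from adenosine receptor A1 (Homo sapiens), read by scintillation counting, tested at 10 uM; on this read-out higher numbers stand for more inhibition at the one concentration tested (going by the name of the read-out) and lower numbers for less inhibition. Compound 1 `COc1ccc(-c2sc(N)c(C(=O)c3ccc(Cl)cc3)c2C)cc1` gives 1%. Compound 2 `CC(C)(C)Cc1csc(N)c1C(=O)c1cccc(Cl)c1` gives 2% in this assay. Compound 3 `CC(C)(C)Cc1c(-c2ccoc2)sc(N)c1C(=O)c1ccc(Cl)cc1` gives 1% in this assay.

Compound 3 stands level with compound 1 at the digits shown, the two together giving the lowest of the three numbers; the number of compound 2 is the one furthest from it, and that gap, like the gap to compound 1, lies within the scatter. All three numbers sit within the scatter of one another, so no order among them is claimed.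

Compound 4 `CC(C)(C)Cc1c(-c2ccccn2)sc(N)c1C(=O)c1ccc(Cl)cc1` has not been measured. It differs from compound 3 in one place: pyridin-2-yl in place of furan-3-yl on an aromatic carbon. Going by the values given here, no step between measured compounds bears on this change, and nothing among the measured compounds shows a group at that place moving the number. The step from compound 3 to compound 4 is expected to be a number 2 percentage points higher from compound 3 to compound 4 (within the scatter), nothing beyond the scatter in this assay. Compound 4 is estimated at 3% in this assay, within -8% to 14%.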

Compound 4, a percentage reported as inhibition, at one concentration (the size of the read-out at that concentration, not a potency): 1%
Estimate against measurement, compound 4: 2 percentage points above; measured number inside the range.
By their numbers in this assay, from the lowest: compounds 1, 3, 4 and 2 (each within the scatter of the next).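

In this assay, going by these compounds alone, the exchange of furan-3-yl for pyridin-2-yl on the aromatic carbon next to the ring sulfur gives no change at the digits printed from compound 3 to compound 4 (within the scatter) and is the first step that can be read at this place. A five-membered and a six-membered aromatic ring, each with 1 hetero atom, therefore stand here without a difference that this pair can resolve, although this one pair cannot speak for other groups. No measurement is available that would explain this result.

Going by these compounds, what a carboxylic acid, a primary amine or a longer alkyl chain would do at this place remains open. Also open, on these data alone, is whether any group here can move the number beyond the scatter, and whether the same exchange would read alike without the neopentyl group.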